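Thioether arm variation on the shared core

The source may report more compounds than this note shows. Statements on the series, on what has been measured and on what is new or still open speak of the compounds shown alone.

For the measured compounds named here, the shared core carries a thioether arm whose terminal group is the only point of change. Compound 1 `N#Cc1c(N)nc(SCc2cccc(C(N)=O)c2)c(C#N)c1-c1ccc(OCC2CC2)cc1` gives 1% in an assay on CHO cells for displacement of a labelled ligand from adenosine receptor A3 (Homo sapiens), read by scintillation counting, with a stated time of 120 min, tested at 1 uM; on this read-out higher numbers stand for more inhibition at the one concentration tested (going by the name of the read-out) and lower numbers for less inhibition. Compound 2 `N#Cc1c(N)nc(SCc2cnc[nH]2)c(C#N)c1-c1ccc(OCC2CC2)cc1` gives 1% in this assay. Compound 3 `N#Cc1c(N)nc(SCC2=NCCN2)c(C#N)c1-c1ccc(OCC2CC2)cc1` gives 6% in this assay, numerically the highest of the three, though compound 1 as nearest and compound 2 as furthest both sit within the scatter of it. The measured steps are no change at the digits printed from compound 1 to compound 2 (within the scatter), a number 5 percentage points higher from compound 1 to compound 3 (within the scatter) and a number 5 percentage points higher from compound 2 to compound 3 (within the scatter); every exchange at the saturated chain carbon bound to a sulfur has left the read-out near its floor.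

Compound 4 `N#Cc1c(N)nc(SCc2ncn[nH]2)c(C#N)c1-c1ccc(OCC2CC2)cc1` differs from compound 3 in one place: a group of 5 heavy atoms (2 carbon, 3 nitrogen; one five-membered aromatic ring with 3 hetero atoms) in place of a group of 5 heavy atoms (3 carbon, 2 nitrogen; one five-membered non-aromatic ring with 2 hetero atoms), on a saturated chain carbon bound to a sulfur. The step that bears most directly on this is a number 5 percentage points higher from compound 2 to compound 3 (within the scatter), a swap of one five-membered ring for another at the same place that stayed within the scatter, and a number 5 percentage points higher from compound 1 to compound 3 (within the scatter) points the same way. No movement beyond the scatter is therefore expected in this assay, and the expected step is a number 3 percentage points lower from compound 3 to compound 4 (within the scatter). Compound 4 is estimated at 3% in this assay, with a range from 0% to 12%.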

Compound 4, a percentage reported as inhibition, at one concentration (the size of the read-out at that concentration, not a potency): 1%
Estimate against measurement, compound 4: 2 percentage points above; the range from low to high includes it.
By their numbers in this assay, from the lowest: compounds 1, 2, 4 and 3 (each within the scatter of the next).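

The 1H-1,2,4-triazol-5-yl group at the saturated chain carbon bound to a sulfur gives, in this assay, a number 5 percentage points lower from compound 3 to compound 4 (within the scatter), no change at the digits printed from compound 2 to compound 4 (within the scatter) and no change at the digits printed from compound 1 to compound 4 (within the scatter). For the compounds shown here, its exchange for 1H-imidazol-5-yl adds what the earlier compounds did not show: going from a five-membered aromatic ring with 2 hetero atoms to one with 3 leaves the read-out where it was, so the four terminal groups, one six-membered aromatic ring of carbon only and three different five-membered rings, all lie within the scatter of one another at this place. No independent evidence bears on this result, and the flat picture stays without explanation.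

Still open, as far as these compounds go, is whether any terminal group at this place lifts the read-out beyond the scatter in this assay, for instance a primary amine, a carboxylic acid, or a longer chain between the sulfur and the ring. With a read-out at a single concentration and all values this close together, the compounds shown also give no potency and no ranking of these groups.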